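The compounds below may be only part of what the source reports. "The series", "measured", "known", "first", "only" and "open" are said of these compounds alone.

Measured so far:
- Compound 1 `CCn1c(C(=O)N[C@H](C)C(=O)OC)ccc1C(CC)(CC)c1ccc(OCS(=O)(=O)c2ccccc2)c(C)c1`: > 50000 nM
- Compound 2 `CCn1c(C(=O)NC2(C(=O)O)CC2)ccc1C(CC)(CC)c1ccc(OCS(=O)(=O)c2ccccc2)c(C)c1`: 41200 nM

Among the measured compounds shown here, in a functional assay on MCF7 cells (Homo sapiens) for antiproliferative activity, read by MTT assay, with a stated time of 24 h (on this read-out lower numbers stand for stronger inhibition and higher numbers for weaker inhibition), compound 2 gives 41200 nM, the only true number available. Compound 1 is reported as > 50000 nM, which is a limit of the assay and not a number. That limit is recorded here as the limit of > 50000 nM in this assay, at which 1 of the 2 values shown sits.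

Compound 3 `CCn1c(C(=O)N[C@H](CC(=O)O)C(=O)O)ccc1C(CC)(CC)c1ccc(OCS(=O)(=O)c2ccccc2)c(C)c1` is the next to be tested. It carries 1,2-dicarboxyethyl in place of 1-carboxycyclopropyl on an amide-type nitrogen. For the measured compounds named here, the one measured step that bears on this change alters the same place, and it is an at least 1.2-fold lower number from compound 1 to compound 2 (0.08 log units; that floor lies within the scatter). That step rests on a limit and stays within the scatter, so it offers no sign that changes at this nitrogen move the number much. On that slim evidence, no step beyond the scatter is expected in this assay, although a result reported only as a limit would be no surprise. The expected change is a 1.1-fold higher number from compound 2 to compound 3 (0.04 log units; within the scatter). For compound 3 the estimated value is 45000 nM, with an expected range of 20000 nM to 90000 nM.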

Compound 3, half-maximal inhibitory concentration: > 50000 nM
Compound 3 was reported as a limit (the forecaster's own chance of this, stated with the estimate: 45%); middle value at least 1.1-fold (0.04 log units) away from the limit.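

In this assay the result for compound 3 is a limit of the assay and not a number, and such limits now make up most of the values in this small set: the limit of > 50000 nM in this assay, at which 2 of the 3 values shown sit.

Exchanging 1-carboxycyclopropyl for 1,2-dicarboxyethyl on the amide-type nitrogen gives an at least 1.2-fold higher number from compound 2 to compound 3 (0.08 log units; that floor lies within the scatter), so a second carboxylic acid group and the loss of the three-membered ring together bring no sign of stronger inhibition in this assay. Among the compounds shown here, the step that joins compound 1 to compound 3 links two limits and cannot be read, which leaves compound 2 as the only compound here with a true number.

Going by these compounds, the two parts of this change cannot be told apart, as the ring goes and the second carboxylic acid arrives in the same step, so the effect of each alone remains unknown. On these data alone, it also remains open whether any group on this nitrogen can move the number far from the values seen so far, for example an amine or a longer chain of plain carbon atoms.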